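Removing One Methoxy Group from Compound 2

This account rests on a few compounds, and the source may have more. Where it says the series, first, only, none or still open, it means among the compounds named here.

Of the compounds shown here, three sharing one core have been measured in a functional assay on Malme-3M cells (Homo sapiens) for inhibition, read by sulforhodamine B assay, with a stated time of 48 h; a higher number here means a weaker inhibitor of growth, a lower number a stronger inhibitor of growth. Compound 1 `COc1ccc(-c2cc(/C=C/C(=O)c3ccc(N)cc3)[nH]n2)cc1` gives 2180 nM, compound 2 `COc1cc(-c2cc(/C=C/C(=O)c3ccc(N)cc3)[nH]n2)cc(OC)c1OC` gives 2050 nM, and compound 3 `COc1cc(-c2cc(/C=C/C(=O)c3ccc(F)c(F)c3)[nH]n2)cc(OC)c1OC` gives 2960 nM. Compound 2 stands at the lowest of the three numbers, but both others lie within the scatter of it. Among the compounds with values here, the one step that changes a single part, a 1.4-fold higher number from compound 2 to compound 3 (0.16 log units; within the scatter), concerns the group on the carbonyl carbon, not the part altered here. Compound 4 `COc1ccc(-c2cc(/C=C/C(=O)c3ccc(N)cc3)[nH]n2)cc1OC` differs from compound 2 by hydrogen in place of methoxy on an aromatic carbon. Within the data shown here, no measured step follows this change; the values of compound 1 and compound 2 only show that fewer methoxy groups on that ring left the number similar. A step of a 1.0-fold higher number from compound 2 to compound 4 (0.01 log units; within the scatter) is therefore expected, nothing beyond the scatter. Compound 4 is estimated at 2100 nM, between 1000 nM and 4500 nM.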

Compound 4, concentration for 50% growth inhibition: 6720 nM
Compound 4: the middle estimate sits 3.2-fold (0.51 log units) below what was measured; the measured number lies above the stated range.
By their numbers in this assay, from the lowest: compounds 2, 1 and 3 (each within the scatter of the next); then compound 4.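

In this assay taking this methoxy group away gives a 3.3-fold higher number from compound 2 to compound 4 (0.52 log units; beyond the scatter) and adding a methoxy group to the ring of compound 1 gives a 3.1-fold higher number from compound 1 to compound 4 (0.49 log units; beyond the scatter) as well. The swap between hydrogen and methoxy thus raises the number in both directions, so compound 4, with fewer methoxy groups than compound 2 and more than compound 1, stands apart from those two, which lie within the scatter of each other.

Nothing available explains this pattern. From the compounds shown here alone, how a hydroxyl or an ethoxy group at this place would read also stays open.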